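Trifluoromethyl on the compound 2 core: an expected step

This account rests on a few compounds, and the source may have more. Where it says the series, first, only, none or still open, it means among the compounds named here.

compound 1 `C=C1C=CCO[C@@H]1n1ccc(NC(=O)c2ccccc2)nc1=O`: 368000 nM
compound 2 `O=C1C=CCO[C@@H]1n1ccc(O)nc1=O`: 92000 nM

In a functional assay on L1210 cells (Mus musculus), with a stated time of 2 days (a higher number here means a weaker inhibitor, a lower number a stronger inhibitor), compound 2 gives 92000 nM as the lower of the two numbers. Compound 1 gives 368000 nM as the higher one, and the gap between the two lies beyond the scatter. Compound 3 `O=C1C=CCO[C@@H]1n1cc(C(F)(F)F)c(O)nc1=O` is still unmeasured. It carries trifluoromethyl in place of hydrogen on an aromatic carbon, ortho to a hydroxy group, with trifluoromethyl in place of hydrogen on an aromatic carbon as the counted change. Among the measured compounds shown here, no measured pair shows this change, so the expectation rests on very little. For the measured compounds named here, a moderate step towards a lower number in this assay is expected, somewhat beyond the scatter, though no step at all would not surprise. An estimated 3.1-fold lower number from compound 2 to compound 3 (0.49 log units; beyond the scatter) is the working figure. Compound 3 is expected at 30000 nM within an estimated range of 6000 nM to 120000 nM for now.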

Compound 3, half-maximal inhibitory concentration: 23000 nM
The estimate for compound 3 lay 1.3-fold (0.12 log units) above the measured number, and the stated range covers the measured number.
By their numbers in this assay, from the lowest: compound 3; then compound 2; then compound 1.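

In this assay, among the compounds shown here, trifluoromethyl in place of hydrogen on the aromatic carbon ortho to a hydroxy group gives a 4.0-fold lower number from compound 2 to compound 3 (0.60 log units; beyond the scatter) as the first single-place step, a modest change beyond the scatter. The position therefore accepts a group of 4 heavy atoms with no loss in this read-out, and the number moves towards stronger inhibition. Nothing measured on these compounds accounts for the step, so its origin remains unassigned.

One substituent at one position cannot show whether the step is specific to trifluoromethyl or would also appear with a methyl, a chlorine atom or a nitrile on the same carbon. Also open, on these data alone, is whether trifluoromethyl at this position gives a similar step on the core of compound 1.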